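A carbamate pair and its methyl variant

A few compounds are considered here, and "the series" means these few. Any claim that something is new, unique, unknown or untested is made for them only; others in the source may bear on it.

Measured so far:
Compound 1 `CC(C)COC(=O)N1CCN(C(=O)c2nc(Nc3cc(C4CC4)[nH]n3)c3cc(Cl)ccc3n2)C[C@H]1C` gives 73.7% in an ADME assay on a cell-free system (plasma, Homo sapiens), read by HPLC, with a stated time of 120 min, at 37 degrees C; on this read-out lower numbers stand for a less stable compound and higher numbers for a more stable compound.
Compound 2 `CC(C)C(=O)OCOC(=O)N1CCN(C(=O)c2nc(Nc3cc(C4CC4)[nH]n3)c3cc(Cl)ccc3n2)C[C@H]1C` gives 6.1% in this assay.

Compound 2 stands lowest of the two numbers; its nearest neighbour is compound 1, reached by the step of a number 67.6 percentage points lower from compound 1 to compound 2 (beyond the scatter), which sets compound 2 far apart. Compound 3 `C[C@@H]1CN(C(=O)c2nc(Nc3cc(C4CC4)[nH]n3)c3cc(Cl)ccc3n2)CCN1C(=O)OCOC(=O)C(C)(C)C` differs from compound 2 only by methyl in place of hydrogen on a saturated chain carbon bound to a carbonyl carbon and two saturated chain carbons. Going by the values given here, no measured step covers this single methyl addition. Among the compounds with values here, the one step on record, from compound 1 to compound 2, concerns a different, larger exchange and does not tell how adding a methyl on the carbonyl-bound carbon will read. Because compound 2 gives 6.1% and compound 3 keeps the same ((tert-butyl)carbonyl)oxy-type linkage, compound 3 is expected to stay in the low range, with the step of a number 11.9 percentage points higher from compound 2 to compound 3 (beyond the scatter) taken as an estimate rather than a known figure. The expected value for compound 3 is 18%, within 4% to 50%.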

Compound 3, percent of the compound remaining: 0%
Estimate against measurement, compound 3: 18 percentage points above; the measured number lies below the stated range.
By their numbers in this assay, from the lowest: compounds 3 and 2 (each within the scatter of the next); then compound 1.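

Going from isopropyl to tert-butyl at this place gives, in this assay, a number 6.1 percentage points lower from compound 2 to compound 3 (within the scatter), so adding this methyl on the saturated chain carbon bound to a carbonyl carbon and two saturated chain carbons brings no reading that can be told apart from that of compound 2. The wider exchange of the isopropyl of compound 1 for ((tert-butyl)carbonyl)oxy gives a number 73.7 percentage points lower from compound 1 to compound 3 (beyond the scatter), which shows that this second (carbonyl)oxy group, like the isopropylcarbonyl one, stands far from compound 1 on this read-out. No measurement shown here offers a reason for either result.

On these data alone, what stays open is how a shorter group such as acetyl, or a longer chain, would read at this place. An amine on that chain is equally untested among the compounds shown.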